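Swapping chloro for methyl on a benzylamide side chain

This account rests on a few compounds, and the source may have more. Where it says the series, first, only, none or still open, it means among the compounds named here.

Compound 2, `CC(C)c1c(C(=O)NCc2ccc(Cl)cc2)nn(-c2ccc(F)cc2)c1OC[C@@H](O)C[C@@H](O)CC(=O)O`, compound 1, `Cc1ccc(CNC(=O)c2nn(-c3ccc(F)cc3)c(OC[C@@H](O)C[C@@H](O)CC(=O)O)c2C(C)C)cc1`, compound 3, `CC(C)c1c(C(=O)N(C)Cc2cccc(Cl)c2)nn(-c2ccc(F)cc2)c1OC[C@@H](O)C[C@@H](O)CC(=O)O`, and compound 4, `Cc1cccc(CN(C)C(=O)c2nn(-c3ccc(F)cc3)c(OC[C@@H](O)C[C@@H](O)CC(=O)O)c2C(C)C)c1`, share one core; compound 4 has not yet been tested. In an assay on microsomes from liver for inhibition of 3-hydroxy-3-methylglutaryl-coenzyme A reductase (Rattus norvegicus) (a higher number here means a weaker inhibitor, a lower number a stronger inhibitor), compound 2 gives 6.7 nM, compound 1 gives 15 nM, and compound 3 gives 8.3 nM. Compound 1 differs from compound 2 by methyl in place of chloro on an aromatic carbon. That change gave a 2.2-fold higher number from compound 2 to compound 1 (0.35 log units; beyond the scatter). Compound 3 differs from compound 2 by (3-chlorobenzyl)(methyl)amino in place of (4-chlorobenzyl)amino on a carbonyl carbon. That change gave a 1.2-fold higher number from compound 2 to compound 3 (0.09 log units; within the scatter). Compound 4 differs from compound 3 by methyl in place of chloro on an aromatic carbon. Within the data shown here, this is the same kind of change as the one from compound 2 to compound 1, but not the same change: there the group sat para to a large group, here it sits meta to a large group. Among the measured compounds shown here, for compound 4 the step is expected to resemble the earlier one, a 1.9-fold higher number from compound 3 to compound 4 (0.29 log units; within the scatter), because a 2.2-fold higher number from compound 2 to compound 1 (0.35 log units; beyond the scatter) is the only measured example of this kind of change, and it is modest and rests on a single pair. Compound 4 is therefore expected to give about 16 nM in this assay, likely between 8 nM and 32 nM.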

Compound 4, half-maximal inhibitory concentration: 37 nM
For compound 4 the middle estimate is 2.3-fold (0.36 log units) below the measured one; the whole stated range lies below it.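

In this assay, methyl in place of chloro gave a 4.5-fold higher number from compound 3 to compound 4 (0.65 log units; beyond the scatter), a weaker inhibitor, and the earlier pair moved the same way, so the direction held on both cores and the two sizes cannot be told apart: the same change on two cores in this assay, a 2.2-fold higher number (0.35 log units; beyond the scatter) from compound 2 to compound 1 and a 4.5-fold higher number (0.65 log units; beyond the scatter) from compound 3 to compound 4, 2.0-fold (0.30 log units) apart, within the scatter of two such steps

The other new steps, a 5.5-fold higher number from compound 2 to compound 4 (0.74 log units; beyond the scatter) and a 2.5-fold higher number from compound 1 to compound 4 (0.39 log units; beyond the scatter), replace the whole amine side chain, so they do not isolate the swap of methyl for chloro. Two pairs are too few to make a rule, and because the ring position of the swapped group also differs between them, they cannot show whether that position matters.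

Still open, from the compounds shown here alone, is how other groups on that ring carbon would compare, such as fluoro, methoxy or nitrile, or an ethyl group as a longer chain. Also open is what the methyl on the amide nitrogen contributes alone, since no pair shown changes only that.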